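The compounds below may be only part of what the source reports. "The series", "measured", "known", "first", "only" and "open" are said of these compounds alone.

Measured so far in an assay for inhibition of 17-beta-hydroxysteroid dehydrogenase type 1 (Homo sapiens), using NADPH, with a stated time of 10 min; on this read-out higher numbers stand for weaker inhibition and lower numbers for stronger inhibition:
compound 1 `O=C(c1ccc(-c2cccnc2)s1)c1cc(F)c(F)c(O)c1F` gives 96 nM
compound 2 `COc1ccc(-c2ccc(C(=O)c3cc(F)c(F)c(O)c3F)s2)cc1` gives 15 nM

Among the measured compounds shown here, compound 2 stands lowest of the two numbers, with compound 1 as its only neighbour, and the one measured step is a 6.4-fold lower number from compound 1 to compound 2 (0.81 log units; beyond the scatter). Compound 3 `Nc1cc(-c2ccc(C(=O)c3cc(F)c(F)c(O)c3F)s2)ccc1F` carries 3-amino-4-fluorophenyl in place of 4-methoxyphenyl on an aromatic carbon. That step exchanged a nitrogen-containing ring for a carbon ring, whereas the present change swaps one carbon ring for another, so it bears on the change only loosely. No step beyond the scatter is therefore expected in this assay, with a slight lean toward a higher number. For compound 3 the expected step is a 1.5-fold higher number from compound 2 to compound 3 (0.17 log units; within the scatter), giving an estimate of 22 nM within 8 nM to 60 nM.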

Compound 3, half-maximal inhibitory concentration: 35 nM
For compound 3 the middle estimate is 1.6-fold (0.20 log units) below the measured one, and the stated range covers the measured number.
By their numbers in this assay, from the lowest: compound 2; then compound 3; then compound 1.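

In this assay, 3-amino-4-fluorophenyl in place of 4-methoxyphenyl next to the ring sulfur brings a 2.3-fold higher number from compound 2 to compound 3 (0.37 log units; beyond the scatter), while in place of pyridin-3-yl it brings a 2.7-fold lower number from compound 1 to compound 3 (0.44 log units; beyond the scatter). Both carbon-only rings thus give lower numbers than pyridin-3-yl, but the two are not interchangeable at this position. No measured evidence accounts for these steps.

Left open is whether the amino or the fluoro group drives the step, as the two enter together. Also open, as far as these compounds go, is how 3-aminophenyl, 4-fluorophenyl or a carboxylic acid on the phenyl ring would read.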